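A few compounds are considered here, and "the series" means these few. Any claim that something is new, unique, unknown or untested is made for them only; others in the source may bear on it.

Compound 1 `COC1=C(C)C(=O)/C(=C(O)/C=C/c2ccc(C)cc2)C(=O)C1(C)C` is one of three measured members of this series, and in a functional assay on HCT-8 cells (Homo sapiens) for cytotoxicity (on this read-out higher numbers stand for an effect only at larger amounts of compound and lower numbers for an effect already at smaller amounts), compound 1 gives 4.1 ug/mL. Compound 2 `CCc1ccc(/C=C/C(O)=C2/C(=O)C(C)=C(OC)C(C)(C)C2=O)cc1` carries the change methyl in place of hydrogen on a saturated chain carbon bound to an aromatic carbon relative to compound 1, and in this assay compound 2 gives 10.5 ug/mL. That single change made a 2.6-fold higher number from compound 1 to compound 2 (0.41 log units; beyond the scatter). Compound 3 `CCC1=C(OC)C(CC)(CC)C(=O)C(C(=O)/C=C/c2ccc(C)cc2)=C1O` is built on a different core; the difference between the two cores is not broken down here. In this assay compound 3 gives 9.4 ug/mL, which lies within the scatter of the value of compound 2 and beyond the scatter from the value of compound 1. Compound 4 `CCC1=C(OC)C(CC)(CC)C(=O)C(C(=O)/C=C/c2ccc(CC)cc2)=C1O` is not yet measured. For the measured compounds named here, it differs from compound 3 by methyl in place of hydrogen on a saturated chain carbon bound to an aromatic carbon, the same change at the same place as the one from compound 1 to compound 2. The step from compound 3 to compound 4 in this assay is expected to be a 2.1-fold higher number from compound 3 to compound 4 (0.33 log units; beyond the scatter), set beside the earlier 2.6-fold higher number from compound 1 to compound 2 (0.41 log units; beyond the scatter), a shift in the same direction. That expectation rests on a single measured pair, so it is held loosely. Compound 4 is therefore estimated at 20 ug/mL, most likely between 10 ug/mL and 40 ug/mL.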

Compound 4, concentration for half-maximal effect: 8.5 ug/mL
Compound 4: the middle estimate sits 2.4-fold (0.37 log units) above what was measured; measured number below the stated range.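

In this assay the change from 4-methylphenyl to 4-ethylphenyl gives a 1.1-fold lower number from compound 3 to compound 4 (0.04 log units; within the scatter) so on this core the two compounds cannot be told apart. Set beside the earlier step, the same change does not carry over unchanged from the core of compound 1 to the core of compound 3: the same change on two cores in this assay, a 2.6-fold higher number (0.41 log units; beyond the scatter) from compound 1 to compound 2 and a 1.1-fold lower number (0.04 log units; within the scatter) from compound 3 to compound 4, 2.8-fold (0.45 log units) apart, beyond the scatter of two such steps. This shows that, for these two pairs, a step measured on one core cannot simply be added to a compound on the other, but it does not show which part of the two cores accounts for the gap, and two pairs are too few to make a rule for the series.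

From the compounds shown here alone, it remains open whether a longer chain such as propyl, or a methoxy group or a chlorine atom in the same place, would follow the pattern of the core of compound 1 or that of the core of compound 3. Going by these compounds, it also remains open whether the gap between the two cores would persist for such groups or is confined to the step from methyl to ethyl.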